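Swapping the Amine Substituent on the Meta-Linked Amide

The compounds below may be only part of what the source reports. "The series", "measured", "known", "first", "only" and "open" are said of these compounds alone.

Measured so far:
Compound 1 `CCN(Cc1ccccn1)c1cccc(C(=O)N2CCc3ccc(OS(N)(=O)=O)cc3C2)c1` gives 19.9%.
Compound 2 `CCN(Cc1cccnc1)c1ccc(C(=O)N2CCc3ccc(OS(N)(=O)=O)cc3C2)cc1` gives 85.2%.

Both compounds were tested in an assay on HEK293 cells for inhibition of Steryl-sulfatase (Homo sapiens), tested at 1 uM; a lower number here means a weaker effect, a higher number a stronger effect of the compound at the concentration tested. Among the two numbers, compound 1 stands lowest, and its nearest neighbour, compound 2, lies well beyond the usual scatter above it. Within the data shown here, the two compounds differ in more than one place, so no single step between them is known; their values simply show that compound 1 inhibits little and compound 2 much.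

The unmeasured compound 3 `CC(C)CCN(CCC(C)C)c1cccc(C(=O)N2CCc3ccc(OS(N)(=O)=O)cc3C2)c1` keeps the shared core of compound 1 and changes one group: diisopentylamino in place of ethyl((pyridin-2-yl)methyl)amino on an aromatic carbon. Among the measured compounds shown here, no step between measured compounds tells how such a change behaves here, so any expectation rests only on the weak value of compound 1 and the broad range that compound 2 shows is possible.

For compound 3 the estimate in this assay is 35%, within 10% to 70%. The expected step of a number 15.1 percentage points higher from compound 1 to compound 3 (beyond the scatter) is a modest rise, not clearly beyond the scatter.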

Compound 3, a percentage reported as inhibition, at one concentration (the size of the read-out at that concentration, not a potency): 75.9%
The estimate for compound 3 lay 40.9 percentage points below the measured number; measured number above the stated range.
By their numbers in this assay, from the lowest: compound 1; then compounds 3 and 2 (each within the scatter of the next).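

This step shows that the low value of compound 1 is not fixed by the shared core or by having a substituted amino group at this place. In this assay, diisopentylamino in place of ethyl((pyridin-2-yl)methyl)amino, on the aromatic carbon meta to a large group, gives a number 56 percentage points higher from compound 1 to compound 3 (beyond the scatter), so compound 3 reaches 75.9% with no ring at all in the entering group. Nothing available here explains why the read-out rises.

The change replaces the whole group at once: the pyridine ring and the ethyl chain leave together, and two isopentyl chains enter, so these compounds cannot show which part of the change matters. A smaller diethylamino group, a mixed ethyl(isopentyl)amino group or a benzyl group in place of the pyridinylmethyl group would help separate these parts, while a full concentration series would be needed to show how the effect changes beyond the single concentration tested.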